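From fluoro to trifluoromethyl: a first number past the limit?

A few compounds are considered here, and "the series" means these few. Any claim that something is new, unique, unknown or untested is made for them only; others in the source may bear on it.

In a functional assay on Mahlavu cells (Homo sapiens) for cytotoxicity, read by sulforhodamine B assay, with a stated time of 72 h (a higher number here means a weaker inhibitor, a lower number a stronger inhibitor), compound 1 `OC[C@H]1O[C@@H](n2cnc3c(N4CCN(c5ccccc5)CC4)ncnc32)[C@H](O)[C@@H]1O` gives > 100000 nM, which is a limit of the assay. Compound 2 `OC[C@H]1O[C@@H](n2cnc3c(N4CCN(c5ccc(F)cc5)CC4)ncnc32)[C@H](O)[C@@H]1O` gives > 100000 nM, which is also a limit. Within the data shown here, the series so far therefore rests entirely on (the limit of > 100000 nM in this assay, at which 2 of the 2 values shown sit), and compound 2 has no number of its own.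

Compound 3 `OC[C@H]1O[C@@H](n2cnc3c(N4CCN(c5ccc(C(F)(F)F)cc5)CC4)ncnc32)[C@H](O)[C@@H]1O` has trifluoromethyl in place of fluoro on an aromatic carbon, para to a large group: trifluoromethyl in place of fluoro on an aromatic carbon. Among the measured compounds shown here, the only measured step that bears on this is a step that the two limits leave unreadable from compound 1 to compound 2, fluoro in place of hydrogen, and it offers no size to carry over. The expectation is thus loose: a move towards stronger inhibition, with a real chance that the result stays at the limit. The expected change is an at least 4.0-fold lower number from compound 2 to compound 3 (0.60 log units; beyond the scatter). For compound 3 the estimated value is 25000 nM, with an expected range from 4000 nM to 100000 nM.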

Compound 3, half-maximal inhibitory concentration: 9200 nM
Estimate against measurement, compound 3: 2.7-fold (0.43 log units) above, within the range that was stated.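

In this assay compound 3 gives the series its first reading that is a number rather than a limit, so this aromatic carbon can respond to a change, although the step from hydrogen to fluoro cannot be read. Trifluoromethyl in place of fluoro brings an at least 10-fold lower number from compound 2 to compound 3 (1.03 log units; beyond the scatter), and trifluoromethyl in place of hydrogen brings an at least 10-fold lower number from compound 1 to compound 3 (1.03 log units; beyond the scatter). Both sizes are only lower bounds, because neither compound 1 nor compound 2 has a number of its own: the limit of > 100000 nM in this assay, at which 2 of the 3 values shown sit.

Going by these compounds, it remains open whether this response is tied to trifluoromethyl or would also appear with chloro, methoxy or a nitrile at the same place. Also open, on these data alone, is how an amine or a carboxylic acid there would read, and how far compound 1 and compound 2 truly lie from compound 3.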